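The source may hold more compounds than are shown below. What is called first, only, known or untested is meant among the compounds shown, and "the series" means these compounds.

In an ADME assay on microsomes (Mus musculus) for metabolic stability (a lower number here means slower removal, a higher number faster removal of the compound), compound 1 `Cc1cc(C(F)(F)F)c2cccc(OCc3c(Cl)ccc(S(=O)(=O)N4CCC[C@H]4C(=O)O)c3Cl)c2n1` gives 13.3 mL/min/kg and stands lowest of the two numbers in hand, with compound 2 `COC[C@@H]1CCCN1S(=O)(=O)c1ccc(Cl)c(COc2cccc3c(C(F)(F)F)cc(C)nc23)c1Cl` at 1620 mL/min/kg on the high side. The change to compound 3 `Cc1cc(C(F)(F)F)c2cccc(OCc3c(Cl)ccc(S(=O)(=O)N4CCC(C#N)CC4)c3Cl)c2n1` is 4-cyanopiperidin-1-yl in place of 2-carboxypyrrolidin-1-yl on a sulfonyl sulfur on a sulfonyl sulfur. For the measured compounds named here, with a 120-fold higher number from compound 1 to compound 2 (2.09 log units; beyond the scatter) as the one measured step that also loses the carboxy group, a large upward step is expected in this assay here, perhaps a smaller one, since no measured compound carries the nitrile or the six-membered ring. The expected size is a 34-fold higher number from compound 1 to compound 3 (1.53 log units; beyond the scatter) for this change. Compound 3 is estimated at 450 mL/min/kg with an expected range of 100 mL/min/kg to 1600 mL/min/kg in this assay.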

Compound 3, clearance: 1720 mL/min/kg
Compound 3: the middle estimate sits 3.8-fold (0.58 log units) below what was measured; measured number above the stated range.
By their numbers in this assay, from the lowest: compound 1; then compounds 2 and 3 (each within the scatter of the next).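

In this assay the exchange on the sulfonyl sulfur gives a 130-fold higher number from compound 1 to compound 3 (2.11 log units; beyond the scatter) and so shows a second group without the carboxy, this one with a nitrile on a six-membered ring, also far above compound 1. Exchanging 2-(methoxymethyl)pyrrolidin-1-yl for 4-cyanopiperidin-1-yl gives a 1.1-fold higher number from compound 2 to compound 3 (0.03 log units; within the scatter) and separates neither ring size nor nitrile from the methoxymethyl group. Still open, going by these compounds, is whether a carboxylic acid on another ring, as in 4-carboxypiperidin-1-yl, would stay as low as compound 1. Nothing at hand accounts for the low number of compound 1.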